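Triazole-linked chromenone series: sulfur for nitrogen at the linker

The source may report more compounds than this note shows. Statements on the series, on what has been measured and on what is new or still open speak of the compounds shown alone.

Among the compounds with values here, compound 2 `O=c1cc(-n2cc(CNc3ccccc3)nn2)c2cc(Br)ccc2o1` shows the highest of the two numbers so far. In a functional assay on SW480 cells (Homo sapiens) for antiproliferative activity, read by MTT assay, with a stated time of 48 h (on this read-out lower numbers stand for stronger inhibition and higher numbers for weaker inhibition), compound 2 gives 18400 nM, whereas compound 1 `O=c1cc(-n2cc(-c3ccccc3)nn2)c2cc(Br)ccc2o1` gives 6660 nM. Within the data shown here, the one measured step, a 2.8-fold higher number from compound 1 to compound 2 (0.44 log units; beyond the scatter), was a change from phenyl to anilinomethyl on the triazole and is the only comparison available.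

Compound 3 `O=c1cc(-n2cc(CSc3ccccc3)nn2)c2cc(Br)ccc2o1` differs from compound 2 by phenylsulfanyl in place of anilino on a saturated chain carbon bound to an aromatic carbon. Among the measured compounds shown here, no measured step covers this exchange; the step from compound 1 to compound 2 concerns the insertion of the anilinomethyl linker, not the swap of its heteroatom, so it bears only indirectly. The expected step in this assay is therefore small and of uncertain direction, probably within the scatter. Compound 3 is estimated at 13000 nM, with a range from 5000 nM to 35000 nM. This expectation corresponds to a step of a 1.4-fold lower number from compound 2 to compound 3 (0.15 log units; within the scatter).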

Compound 3, half-maximal inhibitory concentration: 15400 nM
For compound 3 the middle estimate is 1.2-fold (0.07 log units) below the measured one; low and high end bracket the measured number.
By their numbers in this assay, from the lowest: compound 1; then compounds 3 and 2 (each within the scatter of the next).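

In this assay, the exchange of anilino for phenylsulfanyl on a saturated chain carbon bound to an aromatic carbon gives a 1.2-fold lower number from compound 2 to compound 3 (0.08 log units; within the scatter) and so removes the hydrogen-bond donor of the anilino group without a step beyond the scatter. The second linked compound also reads apart from the directly attached phenyl, with a 2.3-fold higher number from compound 1 to compound 3 (0.36 log units; beyond the scatter) in this comparison, so compounds 2 and 3 both stand modestly higher than compound 1 and neither goes against that pattern. No measurement is available that would account for these numbers.

Open, as far as these compounds go, is whether phenoxymethyl, with oxygen as the linking atom, would also stay within the scatter of compounds 2 and 3. Also open, from the compounds shown here alone, is how a longer chain between the aromatic carbon and the phenyl ring would read.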